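The source may hold more compounds than are shown below. What is called first, only, known or untested is meant among the compounds shown, and "the series" means these compounds.

Measured so far in an assay on isolated protein for displacement of a labelled ligand from metabotropic glutamate receptor 5 (Homo sapiens), with a stated time of 60 min, tested at 1 uM; a lower number here means less inhibition, a higher number more inhibition at the concentration tested (going by the name of the read-out):
- compound 1, `Cc1ccc(S(=O)(=O)c2cnc3cc(Cl)ccc3c2N2CCC(C)CC2)cc1F`: 85%
- compound 2, `COc1ccc(S(=O)(=O)c2cnc3cc(F)ccc3c2N2CCC(C)CC2)cc1OC`: 83%
- compound 3, `CC1CCN(c2c(S(=O)(=O)c3ccc(F)cc3)cnc3cc(F)ccc23)CC1`: 74.5%

Compound 3 sits at the bottom of the three numbers. Its gap to compound 2 lies within the scatter, so the two are not told apart, while compound 1 stands above compound 3 by a margin beyond the scatter.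

Compound 4, `Cc1ccc(S(=O)(=O)c2cnc3cc(F)ccc3c2N2CCC(C)CC2)cc1F`, is not yet measured. Its difference from compound 3: 3-fluoro-4-methylphenyl in place of 4-fluorophenyl on a sulfonyl sulfur

For the measured compounds named here, only one measured step touches the sulfonyl aryl group: a number 8.5 percentage points lower from compound 2 to compound 3 (within the scatter). That change was within the scatter, so the group on the sulfonyl sulfur has so far moved this assay little. Going by the values given here, compound 1 carries the same 3-fluoro-4-methylphenyl as compound 4, but its core differs from that of compound 3, so no step between them is counted; its value simply shows that this group is compatible with the high end of the range seen here.

For compound 4 an upward move is therefore expected, a number 7.5 percentage points higher from compound 3 to compound 4 (within the scatter), modest and not certainly beyond the scatter. The estimate for compound 4 is 82%, with a range from 74% to 90%.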

Compound 4, a percentage reported as inhibition, at one concentration (the size of the read-out at that concentration, not a potency): 89%
Compound 4: the middle estimate sits 7 percentage points below what was measured; the range from low to high includes it.
By their numbers in this assay, from the lowest: compounds 3, 2, 1 and 4 (each within the scatter of the next, the first and the last beyond it).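

For the compounds shown here, with 3-fluoro-4-methylphenyl in place of 4-fluorophenyl on a sulfonyl sulfur, this assay gives a number 14.5 percentage points higher from compound 3 to compound 4 (beyond the scatter), the first single-place step at this position to clear the scatter and so the first sign that the aryl group here can shift the read-out. The high end remains unresolved: 3-fluoro-4-methylphenyl in place of 3,4-dimethoxyphenyl gives a number 6 percentage points higher from compound 2 to compound 4 (within the scatter), and fluoro in place of chloro on an aromatic carbon gives a number 4 percentage points higher from compound 1 to compound 4 (within the scatter), so neither change separates these compounds. Nothing available bears on why the 3>4 change raises the number.

Still open, as far as these compounds go, is whether the fluoro or the methyl of the entering group carries the step, which 3-fluorophenyl and 4-methylphenyl would separate. Also open, from the compounds shown here alone, is how this position responds to an aryl group bearing an amine or a carboxylic acid.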